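This account rests on a few compounds, and the source may have more. Where it says the series, first, only, none or still open, it means among the compounds named here.

Values in a functional assay on SMMC-7721 cells (Homo sapiens) for cytotoxicity, read by MTT assay, with a stated time of 72 h; on this read-out higher numbers stand for weaker inhibition and lower numbers for stronger inhibition:
- compound 1 `CCC(C)=C1C(=O)N(c2ccc(Cl)cc2)N(c2ccc(Cl)cc2)C1=O`: 49200 nM
- compound 2 `CN(C)c1ccc(C=C2C(=O)N(c3ccc(Cl)cc3)N(c3ccc(Cl)cc3)C2=O)cc1`: > 128000 nM, a limit of the assay and not a number
- compound 3 `O=C1C(=Cc2ccc(Br)cc2)C(=O)N(c2ccc(Cl)cc2)N1c1ccc(Cl)cc1`: 16600 nM

Among the two actual numbers in this assay, compound 1 gives 49200 nM and compound 3 gives 16600 nM, so compound 3 holds the lower number, and the gap lies beyond the scatter.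

The next compound to be measured is compound 4 `O=C1C(=Cc2cccc(Cl)c2)C(=O)N(c2ccc(Cl)cc2)N1c1ccc(Cl)cc1`, which differs from compound 3 as follows: 3-chlorophenyl in place of 4-bromophenyl on a double-bonded chain carbon bound to a double-bonded ring carbon. In words, this is 3-chlorophenyl in place of 4-bromophenyl on a double-bonded chain carbon bound to a double-bonded ring carbon.

For the measured compounds named here, only one measured step bears on this group: an at least 7.7-fold lower number from compound 2 to compound 3 (0.88 log units; beyond the scatter), with bromo in place of dimethylamino on an aromatic carbon. That step starts from a limit, so it gives a bound and not an exact size. Going by the values given here, it also replaces dimethylamino, not one halogen with another, and no measured pair tests a 3-chlorophenyl group. The estimate therefore stays close to compound 3 at 16600 nM, with a wide range.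

The expected change is a 1.2-fold higher number from compound 3 to compound 4 (0.08 log units; within the scatter), with no step beyond the scatter expected in either direction in this assay. For compound 4 the estimated value is 20000 nM, with an expected range from 7000 nM to 60000 nM.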

Compound 4, half-maximal inhibitory concentration: 20200 nM
The estimate for compound 4 lay 1.0-fold (0.00 log units) below the measured number, and the stated range covers the measured number.
By their numbers in this assay, from the lowest: compounds 3 and 4 (each within the scatter of the next); then compound 1. At a limit, above all of these: compound 2.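

In this assay, 3-chlorophenyl in place of 4-bromophenyl on a double-bonded chain carbon bound to a double-bonded ring carbon gives a 1.2-fold higher number from compound 3 to compound 4 (0.09 log units; within the scatter), so this exchange of aryl groups does not separate the two compounds. For the compounds shown here, a second halogen-bearing phenyl group now also stands clear of the 4-(dimethylamino)phenyl compound, with an at least 6.3-fold lower number from compound 2 to compound 4 (0.80 log units; beyond the scatter) alongside the earlier at least 7.7-fold lower number from compound 2 to compound 3 (0.88 log units; beyond the scatter), and within compounds 2, 3 and 4 no compound goes against this pattern. Compound 2 is held at a limit and not a number, so both of these steps give only a bound on the size of the gap: the limit of > 128000 nM in this assay, at which 1 of the 4 values shown sits.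

Compounds 3 and 4 differ in both the halogen and where it stands on the phenyl group, and the pair cannot show whether either change alone would matter or whether the two happen to offset each other. As far as these compounds go, how a 4-chlorophenyl group, an unsubstituted phenyl group or a phenyl group bearing a carboxylic acid would read at this place remains open.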